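Benzyl ether variants and cytotoxicity in HEL cells

This account rests on a few compounds, and the source may have more. Where it says the series, first, only, none or still open, it means among the compounds named here.

Measured so far:
- Compound 1, `CCC1(Cc2ccccc2)OS(=O)(=O)C=C1OCC(=O)OC`, in an ADME assay on HEL cells (Homo sapiens) for cytotoxicity, with a stated time of 3 days (a lower number here means that less compound is tolerated, a higher number that more compound is tolerated), reaches only a limit, > 200000 nM.
- Compound 2, `CCC1(Cc2ccccc2)OS(=O)(=O)C=C1OCc1ccc(Cl)c(Cl)c1`, gives 36700 nM.
- Compound 3, `CCC1(Cc2ccccc2)OS(=O)(=O)C=C1OCc1ccccc1`, gives 200000 nM.

Compound 3 holds the highest of the two actual numbers; its nearest neighbour is compound 2, with a 5.4-fold higher number from compound 2 to compound 3 (0.74 log units; beyond the scatter). The value for compound 1 is a limit, so the gap from compound 1 to compound 3 cannot be sized, as a number no higher from compound 1 to compound 3 (the limit leaves the size open) shows. Compound 4, `CCC1(Cc2ccccc2)OS(=O)(=O)C=C1OCc1ccc([N+](=O)[O-])cc1`, is the next member: nitro in place of hydrogen on an aromatic carbon. Within the data shown here, two measured steps touch the group on the ether carbon. an at least 5.4-fold lower number from compound 1 to compound 2 (0.73 log units; beyond the scatter) and a 5.4-fold higher number from compound 2 to compound 3 (0.74 log units; beyond the scatter) both place the 3,4-dichlorophenyl at a lower number than phenyl or methoxycarbonyl, so this position does move the read-out; the step involving compound 1 sits at the limit of > 200000 nM in this assay, at which 1 of the 3 values shown sits, and leaves its size open. Among the measured compounds shown here, no measured step tests nitro on the phenyl, so the direction for compound 4 rests only on the observation that a substituted phenyl gave a lower number than the bare phenyl. A modest drop is expected, a 2.0-fold lower number from compound 3 to compound 4 (0.30 log units; within the scatter), though a value at the limit would not be surprising. Compound 4 is estimated at 100000 nM, within 30000 nM to 200000 nM.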

Compound 4, half-maximal cytotoxic concentration: < 200000 nM
Compound 4: no number, only a limit; the forecaster's own chance of this, stated with the estimate: 30%; the middle value lies beyond the limit too.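

In this assay compound 4 returns a limit and not a number: the limit of < 200000 nM in this assay, at which 1 of the 4 values shown sits. The record against the bare phenyl and the methoxycarbonyl is a number no higher from compound 3 to compound 4 (the limit leaves the size open) and a number no higher from compound 1 to compound 4 (the limit leaves the size open), so nitro on this aromatic carbon, para to a large group, adds a direction and no size. The step from compound 2 to compound 4 cannot be read, which leaves the 3,4-dichlorophenyl of compound 2, at 36700 nM, as the only substituted phenyl in the series with an actual number, and a single substituted example is no trend for this position.

Still open, as far as these compounds go, is whether the 4-nitrophenyl sits near the phenyl of compound 3 or as low as the 3,4-dichlorophenyl, which needs an actual number for compound 4 in this assay. An amine or a carboxylic acid in place of the nitro, or a single chlorine in place of hydrogen on the same aromatic carbon, would show whether the lower number of compound 2 extends to other substituted phenyl groups or stays with the 3,4-dichlorophenyl alone.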